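Methyl Substitution Steps in a Cytotoxicity Series

This account rests on a few compounds, and the source may have more. Where it says the series, first, only, none or still open, it means among the compounds named here.

Compound 1 `c1ccc(Nc2nc(-n3cnc4ccccc43)cs2)cc1` and compound 2 `Cc1nccn1-c1csc(Nc2ccccc2)n1` share no counted difference; the difference between the two cores is not broken down here. Both are weak in a functional assay on RKO cells (Homo sapiens) for cytotoxicity, read by resazurin assay, with a stated time of 72 h; on this read-out higher numbers stand for weaker inhibition and lower numbers for stronger inhibition. Compound 1 gives > 100000 nM, a limit of the assay. Compound 2 gives > 100000 nM, also a limit. Compound 3 `Cc1nc2ccccc2n1-c1csc(Nc2ccccc2)n1` gives 50000 nM in this assay. The change methyl in place of hydrogen on an aromatic carbon therefore produces an at least 2.0-fold lower number from compound 1 to compound 3 (0.30 log units; that floor lies within the scatter); one side of that step rests on (the limit of > 100000 nM in this assay, at which 2 of the 3 values shown sit), which is the limit of compound 1.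

Compound 4 `Cc1ccc(Nc2nc(-n3ccnc3C)cs2)cc1` carries the same kind of change, (methyl in place of hydrogen on an aromatic carbon), but the place differs: in compound 3 the methyl sits on a five-membered aromatic ring with 2 nitrogen, between two ring nitrogen atoms, whereas in compound 4 it sits on a six-membered aromatic ring of carbon only, para to a large group. Given that compound 2 gives only a limit, > 100000 nM, compound 4 is expected to show a number no higher from compound 2 to compound 4 (the limit leaves the size open), most likely remaining a limit, and is estimated in this assay at 100000 nM, between 40000 nM and 300000 nM.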

Compound 4, half-maximal inhibitory concentration: > 100000 nM
Compound 4 was reported as a limit; the forecaster's own chance of this, stated with the estimate: 65%; the middle value lies on the limit itself.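

No step can be read from compound 2 to compound 4, since both results are limits: the limit of > 100000 nM in this assay, at which 3 of the 4 values shown sit.

Still open, going by these compounds, is whether methyl on the six-membered aromatic ring of carbon only changes the read-out at all.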